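The compounds below may be only part of what the source reports. "The series", "measured", "known", "first", "only" and "open" are said of these compounds alone.

Measured in a functional assay for inhibition; a lower number here means a stronger inhibitor, a higher number a weaker inhibitor:
- compound 1 `CC(C)(C)c1cc(-c2cc(=O)c3ccc(OCC(=O)O)cc3o2)cc(C(C)(C)C)c1O`: 3000 nM; 100 nM (2 entries)
- compound 2 `CCOC(=O)COc1ccc2c(=O)cc(-c3cc(C(C)(C)C)c(O)c(C(C)(C)C)c3)oc2c1`: 3000 nM
- compound 3 `CN(C)CCCOc1ccc2c(=O)cc(-c3cc(C(C)(C)C)c(O)c(C(C)(C)C)c3)oc2c1`: 700 nM

Among the measured compounds shown here, compound 3 holds the lowest of the single numbers, while compound 1 has no single number, as the several entries of compound 1 in this assay, 3000 nM; 100 nM (2 entries) shows. Compound 4 `CCN(CC)C(=O)COc1ccc2c(=O)cc(-c3cc(C(C)(C)C)c(O)c(C(C)(C)C)c3)oc2c1` carries diethylcarbamoyl in place of 2-(dimethylamino)ethyl on a saturated chain carbon bound to an oxygen on an aromatic ring. For the measured compounds named here, one measured step bears on this place, a 4.3-fold lower number from compound 2 to compound 3 (0.63 log units; beyond the scatter), and it is modest. The entering diethylcarbamoyl resembles the ethoxycarbonyl of compound 2 in carrying a carbonyl, so part of that step should be reversed. The expected change is modest and toward a higher number, a 2.1-fold higher number from compound 3 to compound 4 (0.33 log units; beyond the scatter). In this assay, compound 4 is estimated at 1500 nM, with an expected range of 450 nM to 5000 nM.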

Compound 4, half-maximal inhibitory concentration: 3000 nM
Beside the measured number, compound 4's estimate is 2.0-fold (0.30 log units) below it; the measured number falls inside the stated range.
By their numbers in this assay, from the lowest: compound 3; then compounds 2 and 4 (each within the scatter of the next).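

In this assay, the change from the amine chain to the amide chain gives a 4.3-fold higher number from compound 3 to compound 4 (0.63 log units; beyond the scatter), so the lower number of compound 3 does not carry over to this carbonyl-bearing chain. Exchanging ethoxy for diethylamino on the carbonyl carbon gives no change at the digits printed from compound 2 to compound 4 (within the scatter), which leaves the ester and the amide indistinguishable at this position. Nothing measured here accounts for either step.

Where the carboxylic acid of compound 1 stands against them remains open: the several entries of compound 1 in this assay, 3000 nM; 100 nM (2 entries)

As far as these compounds go, whether a longer chain ending in dimethylamino, or a primary amine, would lower the number also remains open.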